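The source may report more compounds than this note shows. Statements on the series, on what has been measured and on what is new or still open speak of the compounds shown alone.

Working notes on the series. In a functional assay on A-375 cells (Homo sapiens) for activation, with a stated time of 3 days (on this read-out higher numbers stand for an effect only at larger amounts of compound and lower numbers for an effect already at smaller amounts), compound 3 `O=C(Nc1ccc(-c2cscn2)cc1)C1CCCN(Cc2cccc(F)c2)C1` at 5000 nM sits within the scatter of compound 1 `O=C(Nc1ccc(-c2cscn2)cc1)[C@@H]1CCCN(Cc2ccc(F)c(F)c2)C1` at 4000 nM, while compound 2 `O=C(Nc1ccc(-c2cscn2)cc1)[C@H]1CCCN(Cc2ccc(F)c(F)c2)C1` at 270 nM lies lower, beyond the scatter. Compound 4 `O=C(Nc1ccc(-c2cscn2)cc1)C1CCCN(Cc2cccc(F)c2F)C1` differs from compound 3 as follows: fluoro in place of hydrogen on an aromatic carbon; 3-fluorobenzyl becomes 2,3-difluorobenzyl. Going by the values given here, the only measured step, a 15-fold lower number from compound 1 to compound 2 (1.17 log units; beyond the scatter), is large, but it reflects configuration alone (the fact that compounds 1 and 2 differ only in the configuration as drawn). Among the compounds with values here, no measured step therefore covers fluoro in place of hydrogen on an aromatic carbon, and no change beyond the scatter is expected in this assay. The expected step is small: a 1.4-fold lower number from compound 3 to compound 4 (0.15 log units; within the scatter). For compound 4 the estimate is 3500 nM, with an expected range of 1200 nM to 9000 nM.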

Compound 4, half-maximal effective concentration: 10000 nM
Compound 4: the middle estimate sits 2.9-fold (0.46 log units) below what was measured; measured number above the stated range.
By their numbers in this assay, from the lowest: compound 2; then compounds 1, 3 and 4 (each within the scatter of the next, the first and the last beyond it).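

In this assay, going by these compounds alone, fluoro on this aromatic carbon, ortho to a fluoro group, gives a 2.0-fold higher number from compound 3 to compound 4 (0.30 log units; within the scatter), the first measured step on this ring. Going from 3-fluorobenzyl to 2,3-difluorobenzyl therefore brings no change beyond the scatter here. Nothing at hand gives a cause for this step.

Compounds 3 and 4 are drawn without configuration at the saturated ring carbon, so the step cannot be assigned to either single form. As far as these compounds go, whether chloro, methoxy or an amine at this position would also stay within the scatter remains open.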